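The source may report more compounds than this note shows. Statements on the series, on what has been measured and on what is new or still open speak of the compounds shown alone.

In a functional assay on HL-60 cells (Homo sapiens) for inhibition, read by resazurin assay, with a stated time of 72 h (a lower number here means a stronger inhibitor, a higher number a weaker inhibitor), compound 3 `COc1ccc(C2CC(=O)N2c2cc(OC)c(OC)c(OC)c2)cc1` gives 76 nM, the middle of the three measured numbers. Compound 1 `CCSc1ccc(C2CC(=O)N2c2cc(OC)c(OC)c(OC)c2)cc1` stands higher at 204 nM, and compound 2 `COc1ccc(C2C(O)C(=O)N2c2cc(OC)c(OC)c(OC)c2)cc1O` stands much lower at 5 nM. Compound 4 `COc1ccc(C2CC(=O)N2c2cc(OC)c(OC)c(OC)c2)cc1O` differs from compound 3 in one place, with hydroxy in place of hydrogen on an aromatic carbon, ortho to a methoxy group: hydroxy in place of hydrogen on an aromatic carbon. Going by the values given here, the only measured single change is a different swap, methoxy in place of ethylsulfanyl, and it gave a 2.7-fold lower number from compound 1 to compound 3 (0.43 log units; beyond the scatter). That modest step suggests a size for a single change but says nothing about direction. The direction comes from compound 2, which carries the same hydroxy and methoxy pair plus a further hydroxy on the core, and reaches 5 nM. No measurement shows how much of its gap to compound 3 belongs to each hydroxy, so only part of that gap is expected here. The expected change is a 3.8-fold lower number from compound 3 to compound 4 (0.58 log units; beyond the scatter), a moderate move towards stronger inhibition. Compound 4 is therefore estimated at 20 nM, with an expected range of 6 nM to 70 nM.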

Compound 4, half-maximal inhibitory concentration: 8 nM
Estimate against measurement, compound 4: 2.5-fold (0.40 log units) above; measured number inside the range.
By their numbers in this assay, from the lowest: compounds 2 and 4 (each within the scatter of the next); then compound 3; then compound 1.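

In this assay, adding a single hydroxy on the aromatic carbon, ortho to a methoxy group, is enough on its own to give a 9.5-fold lower number from compound 3 to compound 4 (0.98 log units; beyond the scatter). The step of a 1.6-fold higher number from compound 2 to compound 4 (0.20 log units; within the scatter) removes the hydroxy on the saturated ring carbon and stays within the scatter, so with the aromatic hydroxy in place, that second hydroxy makes no readable difference in this pair. No supporting measurement is available to explain why the aromatic hydroxy has this effect.

Going by these compounds, whether an amine or a fluorine on the same aromatic carbon would match the hydroxy remains open. It is also unknown whether the hydroxy would give a similar step in compound 1, which carries ethylsulfanyl in place of the methoxy group of compound 3.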